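Isopropyl on the core: compound 1 to compound 4

The source may report more compounds than this note shows. Statements on the series, on what has been measured and on what is new or still open speak of the compounds shown alone.

Measured in a functional assay on Bel-7402 cells (Homo sapiens) for antiproliferative activity, read by MTT assay, with a stated time of 72 h; a lower number here means a stronger inhibitor, a higher number a weaker inhibitor:
compound 1 `COc1ccc(Cn2c(C(=O)O)c(CNCc3cccc(O)c3)c3ccccc32)cc1`: > 50000 nM
compound 2 `COc1ccc(Cn2c(C(=O)O)c(CNCc3cccc(OC)c3)c3ccccc32)cc1`: 52900 nM
compound 3 `COc1cccc(CNCc2c(C(=O)O)n(Cc3ccccc3F)c3ccccc23)c1`: > 50000 nM

In this assay compound 1 gives > 50000 nM, which is a limit and not a number. That places compound 1 at the limit of > 50000 nM in this assay, at which 2 of the 3 values shown sit. Compound 4 `COc1ccc(Cn2c(C(=O)O)c(CNCc3cccc(O)c3)c3ccc(C(C)C)cc32)cc1` differs from compound 1 by one change: isopropyl in place of hydrogen on an aromatic carbon. In words, this is isopropyl in place of hydrogen on an aromatic carbon.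

Two measured steps lie nearest: a step that the limit leaves unreadable from compound 1 to compound 2, and a step that the limit leaves unreadable from compound 2 to compound 3. Neither involves this aromatic carbon, and neither has a readable size, so no measured size carries over to the new change. Among the measured compounds shown here, the only number to lean on is compound 2 at 52900 nM. In this assay a small step toward a lower number is expected, held loosely, with no change also possible. The expected move is an at least 1.2-fold lower number from compound 1 to compound 4 (0.09 log units; that floor lies within the scatter). For compound 4 the estimated value is 40000 nM, with an expected range of 12000 nM to 90000 nM.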

Compound 4, half-maximal inhibitory concentration: 9270 nM
The estimate for compound 4 lay 4.3-fold (0.63 log units) above the measured number, and the stated range ends above it.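

Isopropyl in place of hydrogen on this aromatic carbon, para to a fused ring, is the first change in the series with a readable size in this assay: it gives an at least 5.3-fold lower number from compound 1 to compound 4 (0.73 log units; beyond the scatter). The two earlier steps cannot be read, so this carbon is the only place shown where a move in the number can be sized. Compound 1 gives > 50000 nM, which is a limit, so the step has a floor and no known full size: the limit of > 50000 nM in this assay, at which 2 of the 4 values shown sit.

From the compounds shown here alone, only isopropyl stands on this carbon, so it remains open whether the move is specific to that group or would also follow from a methyl, a tert-butyl, a chlorine or an amine there. Also open, going by these compounds, is how isopropyl on this carbon behaves with the 2-fluorophenyl group of compound 3.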